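Swapping the aryl group on compound 2 for a fluorophenyl

The compounds below may be only part of what the source reports. "The series", "measured", "known", "first", "only" and "open" are said of these compounds alone.

Compound 1, `O=C(O)c1ccccc1-c1ccc(CCc2ncc(CC3CCCC3)[nH]2)cc1`, and compound 2, `COc1ccc(Cc2cnc(CCc3ccc(-c4ccccc4C(=O)O)cc3)[nH]2)cc1`, share a core that carries a carboxylic acid and an imidazole, and differ only in the group hanging from a saturated chain carbon bound to an aromatic carbon. In an in vitro functional assay on cells for agonist activity at Bombesin receptor subtype-3 (Homo sapiens), read by luminescence and calcium flux (a higher number here means that more compound is needed for the effect, a lower number that less compound is needed), compound 1 gives 133 nM, while compound 2 gives 5360 nM. For the measured compounds named here, compound 2 therefore stands at the highest of the two numbers, and the one step measured so far, a 40-fold higher number from compound 1 to compound 2 (1.61 log units; beyond the scatter), shows how much more compound was needed once the cyclopentyl was replaced by an aromatic ring.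

Compound 3, `O=C(O)c1ccccc1-c1ccc(CCc2ncc(Cc3ccccc3F)[nH]2)cc1`, keeps that aromatic ring but changes its substituent: 2-fluorophenyl in place of 4-methoxyphenyl on a saturated chain carbon bound to an aromatic carbon. Going by the values given here, no measured step compares two aromatic groups at this place, so the only guide is the large step from compound 1 to compound 2, which says the assay is sensitive to what sits there. Compound 3 is expected to move modestly back toward compound 1, with a 2.7-fold lower number from compound 2 to compound 3 (0.43 log units; beyond the scatter). The estimate for compound 3 in this assay is 2000 nM, within a range of 500 nM to 8000 nM.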

Compound 3, half-maximal effective concentration: 177 nM
Beside the measured number, compound 3's estimate is 11-fold (1.05 log units) above it; measured number below the stated range.
By their numbers in this assay, from the lowest: compounds 1 and 3 (each within the scatter of the next); then compound 2.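

The change from 4-methoxyphenyl to 2-fluorophenyl gives a 30-fold lower number from compound 2 to compound 3 (1.48 log units; beyond the scatter) in this assay, so an aromatic ring on this saturated chain carbon does not by itself bring the large rise seen when cyclopentyl gave way to 4-methoxyphenyl. Replacing cyclopentyl directly with 2-fluorophenyl gives a 1.3-fold higher number from compound 1 to compound 3 (0.12 log units; within the scatter), which means that among these three compounds the high number belongs to the 4-methoxyphenyl compound alone, not to aromatic rings as a class. No outside information is available to explain why these two aromatic groups behave so differently.

The two aromatic groups differ both in the substituent, methoxy against fluorine, and in where their names place it, 4 against 2, so the compounds shown cannot say which of these matters. A 2-methoxyphenyl or a 4-fluorophenyl group would separate the two, and an unsubstituted phenyl group would show whether the ring needs any substituent at all to match the number of compound 1, 133 nM.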